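The source may hold more compounds than are shown below. What is called first, only, known or untested is meant among the compounds shown, and "the series" means these compounds.

Working notes on the series, read-out an ADME assay on liver for metabolic stability, with Liver microsome (Homo sapiens) as the target, read by LC-MS, using microsomes, with a stated time of 5 h; on this read-out lower numbers stand for slow clearance and higher numbers for fast clearance. Compound 2 (`C[C@]1(O)C[C@@](c2cc(C(F)(F)F)ccn2)([C@H](O)c2ccccn2)C1`) gives 33.3 mL/min/kg and compound 3 (`O[C@H](c1ccccn1)[C@]1(c2cc(C(F)(F)F)ccn2)C[C@@H](O)C1`) gives 33.3 mL/min/kg, so the two stand level at the low end of the three numbers available. Compound 1 (`CC(O)(c1ccccn1)C1(c2ccc(Cl)c(Cl)c2)CCC1`) gives 1670 mL/min/kg, a much higher number, but it differs from compound 2 in more than one place and offers little guidance here.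

Compound 4 (`C[C@]1(O)C[C@](c2cc(C(F)(F)F)ccn2)([C@H](O)c2ccccn2)C1`) is the next comparison with compound 2: the two compounds have the same atoms and bonds and differ only in configuration as drawn: 2 of 3 stereo elements differ; a stereocentre at a saturated ring carbon is drawn R in compound 2 and S in compound 4; a stereocentre at a saturated ring carbon is drawn s in compound 2 and r in compound 4. For the measured compounds named here, no measured pair isolates a change of configuration. Going by the values given here, the only measured step, no change at the digits printed from compound 2 to compound 3 (within the scatter), swaps a methyl for hydrogen on a saturated ring carbon and so bears on this question only indirectly. It shows the number holding across one change on that ring, while leaving the effect of configuration unknown. On these data alone, a shift beyond the scatter is therefore not expected, and the direction stays open. The expected step is a 1.1-fold higher number from compound 2 to compound 4 (0.06 log units; within the scatter). For compound 4 the estimated clearance is 38 mL/min/kg, with an expected range of 20 mL/min/kg to 85 mL/min/kg.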

Compound 4, clearance: 33.3 mL/min/kg
For compound 4 the middle estimate is 1.1-fold (0.06 log units) above the measured one; low and high end bracket the measured number.
By their numbers in this assay, from the lowest: compounds 2, 3 and 4 (each within the scatter of the next); then compound 1.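

In this assay, for the compounds shown here, the result reads no change at the digits printed from compound 2 to compound 4 (within the scatter), the first measured step that bears on configuration alone. The earlier step changed a substituent, hydrogen in place of methyl on a saturated ring carbon, whereas here nothing leaves or enters, so the comparison isolates configuration: the fact that compounds 2 and 4 differ only in the configuration as drawn For this pair, the two stereocentres at saturated ring carbons can be drawn either way with the clearance number staying level.

The compounds shown leave open whether the third stereo element, drawn alike in compound 2 and compound 4, has any bearing on the number. They also leave open whether this level reading would hold with a different group on a saturated ring carbon, such as an amine or a carboxylic acid.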